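The compounds below may be only part of what the source reports. "The series", "measured", "known", "first", "only" and "open" are said of these compounds alone.

Working notes on the series. Within the data shown here, compound 1 `Cc1cc(C)c(CN2CCc3c(Cl)cc([C@@H](CO)[C@@H]4CCOC4)c(Cl)c3C2=O)c(=O)[nH]1` is the member drawn with defined configuration at both stereocentres of its side chain; in an ADME assay on microsomes from liver (Homo sapiens) for metabolic stability, read by LC-MS, using NADPH, with stated times of 10 min and 45 min, tested at 1 uM (on this read-out higher numbers stand for fast clearance and lower numbers for slow clearance), compound 1 gives 25.3 uL/min, the only single number on record for it, with one further entry that yielded no number. Compound 2 `Cc1cc(C)c(CN2CCc3c(Cl)cc(C(CO)C4CCOC4)c(Cl)c3C2=O)c(=O)[nH]1` carries the same side chain without defined configuration; in this assay compound 2 gives 20 uL/min; 25.9 uL/min (2 entries), and these values sit alongside that of compound 1 within the usual scatter, as seen from the several entries of compound 2 in this assay, 20 uL/min; 25.9 uL/min (2 entries) and (the fact that one of compounds 1 and 2 is drawn with a defined configuration and the other without, at the place where they differ). The step to compound 3 `Cc1cc(C)c(CN2CCc3c(Cl)cc([C@@H](C)CO)c(Cl)c3C2=O)c(=O)[nH]1` is a group of 4 heavy atoms (3 carbon, 1 oxygen; no ring) in place of a group of 8 heavy atoms (6 carbon, 2 oxygen; one five-membered non-aromatic ring with 1 hetero atom), on an aromatic carbon. Among the measured compounds shown here, no measured pair shows a change of this kind, so the size of the step rests on the change alone; the expectation is a step of modest size, toward slower clearance or none beyond the scatter, expected as a 1.3-fold lower number from compound 1 to compound 3 (0.10 log units; within the scatter). Compound 3 is therefore estimated at 20 uL/min in this assay, with a range from 10 uL/min to 40 uL/min.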

Compound 3, intrinsic clearance in a liver preparation (reported as CLH), per the amount of preparation that the assay uses: 12.4 uL/min
Compound 3: the middle estimate sits 1.6-fold (0.21 log units) above what was measured; measured number inside the range.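

In this assay, among these compounds, the aromatic carbon bearing the side chain proves to be a place where the substituent can move clearance: 1-(hydroxymethyl)ethyl in place of the group with the five-membered non-aromatic ring gives a 2.0-fold lower number from compound 1 to compound 3 (0.31 log units; beyond the scatter), the first step that lies beyond the scatter. The step is modest, and the closest measure of repeat variation comes from the related side chain: the several entries of compound 2 in this assay, 20 uL/min; 25.9 uL/min (2 entries). The group without a ring and with fewer heavy atoms therefore gives the lower number in this single pair, with no cause shown.

This one pair cannot separate loss of the ring from loss of size. From the compounds shown here alone, it is also open whether a longer chain in place of 1-(hydroxymethyl)ethyl, or an amine on the same aromatic carbon, would give a number in the same direction.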